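This account rests on a few compounds, and the source may have more. Where it says the series, first, only, none or still open, it means among the compounds named here.

Measured compounds:
- Compound 1 `CN(c1ccc2cc(NC(=O)CCc3ccc(C(F)(F)F)cc3)ccc2n1)C1CCCC1`: 2 nM
- Compound 2 `CC(=O)NC1CCN(c2ccc3cc(NC(=O)CCc4ccc(C(F)(F)F)cc4)ccc3n2)C1`: 5 nM

Both were tested in an assay on isolated protein for displacement of a labelled ligand from melanin-concentrating hormone receptor 1 (Homo sapiens); on this read-out higher numbers stand for weaker inhibition and lower numbers for stronger inhibition. Within the data shown here, compound 2 gives the higher of the two numbers; the only comparison available is to compound 1, which is a 2.5-fold higher number from compound 1 to compound 2 (0.40 log units; beyond the scatter), a step beyond the usual scatter. Compound 3 `CCN(CC)c1ccc2cc(NC(=O)CCc3ccc(C(F)(F)F)cc3)ccc2n1` has not been measured yet. It differs from compound 2 in one place: diethylamino in place of 3-acetamidopyrrolidin-1-yl on an aromatic carbon. This is the same position that was changed in the step from compound 1 to compound 2, where cyclopentyl(methyl)amino gave way to 3-acetamidopyrrolidin-1-yl and the number rose modestly. Compound 3 now carries diethylamino, an acyclic amino group resembling the cyclopentyl(methyl)amino of compound 1 more than the 3-acetamidopyrrolidin-1-yl of compound 2. Among the measured compounds shown here, the one relevant step therefore suggests that undoing that change should bring the number back down by a similar, modest amount, though a single step is a thin basis. For compound 3 the expected step is a 1.7-fold lower number from compound 2 to compound 3 (0.22 log units; within the scatter). Compound 3 is estimated at 3 nM, with a likely range from 1 nM to 9 nM.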

Compound 3, half-maximal inhibitory concentration: 88 nM
The estimate for compound 3 lay 29-fold (1.47 log units) below the measured number, outside the stated range (above it).
By their numbers in this assay, from the lowest: compound 1; then compound 2; then compound 3.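

In this assay, the aromatic carbon next to the ring nitrogen proves far less forgiving than the first pair suggested: the earlier change gave only a 2.5-fold higher number from compound 1 to compound 2 (0.40 log units; beyond the scatter), whereas diethylamino gives an 18-fold higher number from compound 2 to compound 3 (1.25 log units; beyond the scatter) and a 44-fold higher number from compound 1 to compound 3 (1.64 log units; beyond the scatter), both large steps. Diethylamino therefore cannot be treated as a close stand-in for cyclopentyl(methyl)amino, and among these three compounds, the two whose groups contain a ring give much lower numbers than compound 3, whose group has none. No measurement shown here explains why the number rises so sharply at this position.

The compounds shown leave open whether the ring itself matters or whether the difference follows from the overall size of the group, since diethylamino differs from both other groups in more than one respect. A plain pyrrolidine ring attached through its nitrogen, without the acetamide, and dipropylamino, with its longer chains, would help separate these two readings.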